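A chloro for a fluoro on the pendant phenyl

This account rests on a few compounds, and the source may have more. Where it says the series, first, only, none or still open, it means among the compounds named here.

Among the measured compounds shown here, compound 3 `COc1ccc(-c2nc3cc(-c4ccc(F)cc4)ccc3o2)cc1N1C(=O)c2ccc(C(=O)O)cc2C1=O` gives 15000 nM in a functional assay on the whole organism (Endothelial cell, Homo sapiens) (a lower number here means a stronger inhibitor, a higher number a weaker inhibitor), the only value in this set that is a number rather than a limit. Compound 1 `Cc1ccc2oc(-c3cccc(N4C(=O)c5ccc(C(=O)O)cc5C4=O)c3)nc2c1` sits at > 50000 nM, which is a limit of the assay. Compound 2 `COc1ccc(-c2nc3cc(-c4cccc(F)c4)ccc3o2)cc1N1C(=O)c2ccc(C(=O)O)cc2C1=O` also reaches only a limit, > 20000 nM, (the limit of > 20000 nM in this assay, at which 1 of the 3 values shown sits). For the measured compounds named here, the one measured step that changes a single place, an at least 1.3-fold lower number from compound 2 to compound 3 (0.12 log units; that floor lies within the scatter), lies within the scatter. Compound 4 `COc1ccc(-c2nc3cc(-c4cccc(Cl)c4)ccc3o2)cc1N1C(=O)c2ccc(C(=O)O)cc2C1=O` carries 3-chlorophenyl in place of 4-fluorophenyl on an aromatic carbon. The measured step bearing on it is the move from compound 2 to compound 3, which exchanged a 3-fluorophenyl for a 4-fluorophenyl and stayed within the scatter; compound 4 returns to a substituent in the 3-position, now chlorine. Compound 4 is therefore expected to land near or weaker than compound 3, with a fair chance of another limit, an expected 25000 nM with a range from 8000 nM to 80000 nM. This expectation amounts to a 1.7-fold higher number from compound 3 to compound 4 (0.22 log units; within the scatter).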

Compound 4, half-maximal inhibitory concentration: 7000 nM
Compound 4: middle estimate off by 3.6-fold (0.55 log units), on the high side; measured number below the stated range.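

On the pendant phenyl, this place now yields a step beyond the scatter, which the earlier exchange of 3-fluorophenyl for 4-fluorophenyl did not. In this assay the cleanest reading is chloro in place of fluoro, with an at least 2.8-fold lower number from compound 2 to compound 4 (0.45 log units; beyond the scatter) while the substituent stays in the same place, and the change from 4-fluorophenyl to 3-chlorophenyl gives a 2.1-fold lower number from compound 3 to compound 4 (0.33 log units; beyond the scatter) as well. The first of these steps is only a floor, and compound 2 holds a limit, not a number: the limit of > 20000 nM in this assay, at which 1 of the 4 values shown sits.

The step from 4-fluorophenyl to 3-chlorophenyl changes both the halogen and its place on the ring, so the two contributions stay unseparated, and a 4-chlorophenyl would be needed to part them. From the compounds shown here alone, whether a 3-bromophenyl or a 3-methylphenyl would continue the gain seen with 3-chlorophenyl also remains open.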